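Compound 3 to compound 4: dimethylcarbamoyl for isopropylsulfonyl

A few compounds are considered here, and "the series" means these few. Any claim that something is new, unique, unknown or untested is made for them only; others in the source may bear on it.

Compound 1 `CCC(=O)N1C[C@H](NC(=O)c2ccc(-n3ccccc3=O)cc2)[C@H](NC(=O)c2ccc(Cl)s2)C1`: > 100000 nM
Compound 2 `COCCOC(=O)N1C[C@H](NC(=O)c2ccc(-n3ccccc3=O)cc2)[C@H](NC(=O)c2ccc(Cl)s2)C1`: > 100000 nM
Compound 3 `CC(C)S(=O)(=O)N1C[C@H](NC(=O)c2ccc(-n3ccccc3=O)cc2)[C@H](NC(=O)c2ccc(Cl)s2)C1`: > 100000 nM

All three entries come from an ADME assay on HEK293 cells (Homo sapiens) for cytotoxicity (a higher number here means a weaker inhibitor, a lower number a stronger inhibitor), and each is a limit, not a number. Compound 3 stands at the limit > 100000 nM, and the series as measured offers nothing beyond it: the limit of > 100000 nM in this assay, at which 3 of the 3 values shown sit.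

The next structure is compound 4 `CN(C)C(=O)N1C[C@H](NC(=O)c2ccc(-n3ccccc3=O)cc2)[C@H](NC(=O)c2ccc(Cl)s2)C1`. The change is dimethylcarbamoyl in place of isopropylsulfonyl on an amine nitrogen in a ring.

The measured steps that bear on it are a step that the two limits leave unreadable from compound 1 to compound 3, a step that the two limits leave unreadable from compound 2 to compound 3 and a step that the two limits leave unreadable from compound 1 to compound 2. With all three sizes unreadable, the expectation for compound 4 in this assay is no step beyond the scatter, in neither direction, and most likely another limit. The estimated step is a number no higher from compound 3 to compound 4 (the limit leaves the size open). As an estimate, compound 4 is expected at 100000 nM, with a range of 40000 nM to 200000 nM.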

Compound 4, half-maximal inhibitory concentration: > 100000 nM
Compound 4: only a limit was reported; the forecaster's own chance of this, stated with the estimate: 90%; the middle value sits exactly at the limit.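

In this assay compound 4 gives > 100000 nM, which is a limit. Among these compounds, no step from compound 1, compound 2 or compound 3 to compound 4 can be read. The compounds shown leave open whether any substituent on the ring amine nitrogen separates these four compounds in this assay.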